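A few compounds are considered here, and "the series" means these few. Any claim that something is new, unique, unknown or untested is made for them only; others in the source may bear on it.

Measured so far:
- compound 1, `Nc1nn(C(=O)Nc2ccc(Cc3ccccc3)cc2)c2ccccc12`: 46500 nM
- compound 2, `Nc1nn(C(=O)Nc2ccc(Cc3ccccc3)cc2)c2ccc(Cl)cc12`: 16400 nM

Both compounds were tested in a functional assay on HOP-62 cells (Homo sapiens) for antiproliferative activity, read by sulforhodamine B assay, with a stated time of 48 h; on this read-out higher numbers stand for weaker inhibition of growth and lower numbers for stronger inhibition of growth. Compound 2 gives 16400 nM, the lower of the two numbers; compound 1 gives 46500 nM. Among the measured compounds shown here, the one measured step between them is a 2.8-fold lower number from compound 1 to compound 2 (0.45 log units; beyond the scatter), the exchange of a hydrogen for a chloro on an aromatic carbon of the shared core.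

Compound 3, `Nc1ccc2c(c1)c(N)nn2C(=O)Nc1ccc(Cc2ccccc2)cc1`, has not yet been measured. It differs from compound 2 by amino in place of chloro on an aromatic carbon. For the measured compounds named here, only one measured step bears on this change, and only indirectly: a 2.8-fold lower number from compound 1 to compound 2 (0.45 log units; beyond the scatter) shows how much the chloro lowered the number relative to hydrogen. Going by the values given here, no measured compound shows what an amino does at the same place, so the chloro's contribution is given up in compound 3 and the amino's is unknown. The expected result for compound 3 is therefore a step of a 2.1-fold higher number from compound 2 to compound 3 (0.33 log units; beyond the scatter), toward a higher number, most likely landing between the values of compound 2 and compound 1. Compound 3 is estimated at 35000 nM, with a range from 12000 nM to 100000 nM.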

Compound 3, concentration for total growth inhibition: 27000 nM
Beside the measured number, compound 3's estimate is 1.3-fold (0.11 log units) above it; the range from low to high includes it.
By their numbers in this assay, from the lowest: compounds 2, 3 and 1 (each within the scatter of the next, the first and the last beyond it).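

In this assay the amino of compound 3 sits on the same aromatic carbon as the chloro of compound 2, and the step between them is a 1.6-fold higher number from compound 2 to compound 3 (0.22 log units; within the scatter) so these two groups cannot be told apart at this place. Set against hydrogen at that carbon, the step is a 1.7-fold lower number from compound 1 to compound 3 (0.24 log units; within the scatter) so the amino cannot be told apart from hydrogen either, although the chloro and hydrogen compounds do differ beyond the scatter. This position therefore accepts an amino, with the hydrogen-bond donor and acceptor that the chloro lacks, without any step that can be read as a gain or a loss.

Whether the amino truly behaves more like the chloro or more like hydrogen stays open, and nothing measured here offers a reason for these numbers. As far as these compounds go, what a fluoro, a methoxy or a carboxylic acid would give on this same carbon also remains unknown, and such groups would show whether this place responds to the choice of group at all.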